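Ether aryl change from compound 3 to compound 4

The compounds below may be only part of what the source reports. "The series", "measured", "known", "first", "only" and "open" are said of these compounds alone.

The series shares one core carrying an aryloxymethyl group and an aryl on the amide nitrogen. Compound 1 `Cc1ccc(N2CCn3nc(COc4ccccc4)cc3C2=O)cc1` gives 65% in a functional assay on HEK293 cells for positive allosteric modulation of metabotropic glutamate receptor 5 (Homo sapiens), read by calcium flux; a lower number here means a smaller maximal response, a higher number a larger maximal response; compound 2 `COc1ccc(N2CCn3nc(COc4ccccc4)cc3C2=O)cc1` gives 58%; compound 3 `O=C1c2cc(COc3cccc(F)c3)nn2CCN1c1ccc(F)cc1` gives 70%. For the measured compounds named here, the only step between compounds differing in one place, a number 7 percentage points lower from compound 1 to compound 2 (within the scatter), alters the aryl on the amide nitrogen, not the ether side. Compound 3 stands highest of the three numbers, yet its gap to compound 1 is within the scatter, while its gap to compound 2 lies beyond it; compound 3 is thus not set apart from compound 1.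

Compound 4 `O=C1c2cc(COc3ccccn3)nn2CCN1c1ccc(F)cc1` differs from compound 3 in one place: pyridin-2-yl in place of 3-fluorophenyl on an oxygen on a saturated carbon. Going by the values given here, no measured step touches this ether aryl, so the step from compound 1 to compound 2 bears on it only by showing that a single change on an aryl moved the maximal response little. Among the compounds with values here, with no direct precedent, no step beyond the scatter is expected in this assay in either direction. For compound 4 the maximal response is estimated at 65%, within 50% to 80%. The expected step is a number 5 percentage points lower from compound 3 to compound 4 (within the scatter).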

Compound 4, largest response reached (Emax), in percent of the reference or control that the assay uses: 68%
Compound 4: the middle estimate sits 3 percentage points below what was measured, within the range that was stated.
By their numbers in this assay, from the lowest: compounds 2, 1, 4 and 3 (each within the scatter of the next, the first and the last beyond it).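

Pyridin-2-yl in place of 3-fluorophenyl on an oxygen on a saturated carbon is the only step so far that reads the ether aryl directly: in this assay it gives a number 2 percentage points lower from compound 3 to compound 4 (within the scatter) for this one pair. Compound 3 and compound 4 therefore cannot be told apart in this read-out, even though the entering pyridin-2-yl has a ring hetero atom and a hydrogen-bond acceptor that the leaving 3-fluorophenyl does not. Nothing at hand bears on why these two groups read alike.

The step exchanges the fluorine-bearing carbon ring for a nitrogen-containing ring in one move, so the pair does not separate the part played by the fluorine from that of the ring nitrogen. Still open, from the compounds shown here alone, is how the maximal response reads when the ether aryl is replaced by a saturated ring such as cyclohexyl, or when it carries a carboxylic acid or an amine.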